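Chloro for ethyl on the anilide ring of compound 2

The source may hold more compounds than are shown below. What is called first, only, known or untested is meant among the compounds shown, and "the series" means these compounds.

Measured compounds:
- Compound 1, `Cc1ccccc1C(=O)NCCN1CCC(Cc2ccccc2)CC1`, gives 1070 nM in an assay on ileum with histamine H1 receptor (Cavia porcellus) as the target; a higher number here means a weaker inhibitor, a lower number a stronger inhibitor.
- Compound 2, `CCc1ccccc1NC(=O)CCN1CCC(Cc2ccccc2)CC1`, gives 477 nM in this assay.

Of the two numbers shown, compound 2 stands lowest, and compound 1 sits a fair distance above it; that gap lies beyond the scatter of repeated measurements. For the measured compounds named here, the two compounds differ in several places at once, so no single structural step links them, and only their two values can be compared.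

Compound 3, `O=C(CCN1CCC(Cc2ccccc2)CC1)Nc1ccccc1Cl`, has not yet been measured in this assay. It differs from compound 2 in one place only: chloro in place of ethyl on an aromatic carbon. The rest of the molecule is unchanged.

Going by the values given here, no measured pair here shows what such a swap does, so the expectation rests on the closeness of the two structures. The step from compound 2 to compound 3 is expected to be small, a 1.1-fold lower number from compound 2 to compound 3 (0.03 log units; within the scatter), with no clear direction beyond the scatter. For compound 3 the estimated value in this assay is 450 nM, within a range from 150 nM to 1400 nM.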

Compound 3, half-maximal inhibitory concentration: 561 nM
The estimate for compound 3 lay 1.2-fold (0.10 log units) below the measured number; low and high end bracket the measured number.
By their numbers in this assay, from the lowest: compounds 2, 3 and 1 (each within the scatter of the next, the first and the last beyond it).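

In this assay, for the compounds shown here, the swap of 2-ethylphenyl to 2-chlorophenyl gives the first single-place step, a 1.2-fold higher number from compound 2 to compound 3 (0.07 log units; within the scatter). Although ethyl has 2 heavy atoms and chloro has 1, and a carbon chain gives way to a chlorine atom, this aromatic carbon ortho to a large group shows no change that can be told apart from repeat-measurement scatter. Ethyl and chloro therefore cannot be ranked at this position, and in this one pair the change leaves the inhibitor's strength where it was. Nothing available explains this result, so the reason for the matching numbers remains unknown.

The compounds shown leave open whether this position is insensitive to substitution in general or whether ethyl and chloro merely happen to match, a question that a plain hydrogen, a methoxy group, an amine or a carboxylic acid on the same carbon could help settle. They also leave open whether chloro would give a similar number on other carbons of the ring, or with a longer chain joining the amide to the shared core.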